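One Number Among Limits: Estimating Compound 4

The source may report more compounds than this note shows. Statements on the series, on what has been measured and on what is new or still open speak of the compounds shown alone.

Compound 1, `COc1cc(-c2cc(C(=O)O)c3ccccc3n2)ccc1OCC(=O)Nc1ccccc1`, gives in an ADME assay on HaCaT cells (Homo sapiens) for inhibition (on this read-out higher numbers stand for weaker inhibition and lower numbers for stronger inhibition), a result of > 300000 nM, which is a limit of the assay rather than a number.
Compound 2, `COc1cc(-c2cc(C(=O)O)c3ccccc3n2)ccc1OCC(=O)Nc1ccc(C)cc1`, gives in this assay a result of > 300000 nM, again a limit rather than a number.
Compound 3, `COc1cc(-c2cc(C(=O)O)c3ccccc3n2)ccc1OCC(=O)Nc1cccc(Cl)c1`, gives in this assay a value of 192000 nM.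

Among the compounds with values here, compound 3 therefore carries the only actual number among the three; the other two sit at the limit of > 300000 nM in this assay, at which 2 of the 3 values shown sit. The step that the two limits leave unreadable from compound 1 to compound 2 cannot be read at all. The steps of an at least 1.5-fold lower number from compound 1 to compound 3 (0.19 log units; that floor lies within the scatter) and an at least 1.5-fold lower number from compound 2 to compound 3 (0.19 log units; that floor lies within the scatter) each reach only a floor. Compound 4, `COc1cc(-c2cc(C(=O)O)c3ccccc3n2)ccc1OCC(=O)Nc1ccccc1C(F)(F)F`, differs from compound 3 in one place: 2-(trifluoromethyl)phenyl in place of 3-chlorophenyl on an amide-type nitrogen. Within the data shown here, no measured step involves a trifluoromethyl group, and the measured steps only show that changing the substituent on the phenyl ring moved the result by amounts whose floor lies within the scatter. The expected step is therefore a 1.1-fold higher number from compound 3 to compound 4 (0.06 log units; within the scatter), of no clear size in either direction. The estimate for compound 4 in this assay is 220000 nM, with a range from 100000 nM to 450000 nM and a sizeable chance that only a limit is reported.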

Compound 4, half-maximal inhibitory concentration: 102000 nM
Estimate against measurement, compound 4: 2.2-fold (0.33 log units) above; measured number inside the range.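

In this assay, trifluoromethyl in place of hydrogen on the phenyl ring gives an at least 2.9-fold lower number from compound 1 to compound 4 (0.46 log units; beyond the scatter), and 2-(trifluoromethyl)phenyl in place of 4-methylphenyl on the amide-type nitrogen gives an at least 2.9-fold lower number from compound 2 to compound 4 (0.46 log units; beyond the scatter); these are the only readable steps shown that clear the scatter. Both steps are floors rather than sizes, because compound 1 and compound 2 each give only a limit: the limit of > 300000 nM in this assay, at which 2 of the 4 values shown sit. The step from the chlorinated compound stays within the scatter, a 1.9-fold lower number from compound 3 to compound 4 (0.27 log units; within the scatter), so 3-chlorophenyl and 2-(trifluoromethyl)phenyl cannot be told apart here.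

On these data alone, it remains open whether trifluoromethyl itself matters or whether a chloro group at that same place on the ring would read alike. As far as these compounds go, how a nitrile or an amine on that ring would read also remains open.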